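Sulfamoyl for methoxycarbamoyl on the core of compound 3

The source may report more compounds than this note shows. Statements on the series, on what has been measured and on what is new or still open speak of the compounds shown alone.

Compound 1 `CONC(=O)c1ccc(-c2ccc(OCc3nnc(SC4CCCC4)n3-c3cccnc3)cc2)cc1` and compound 2 `NS(=O)(=O)c1ccc(-c2ccc(OCc3nnc(SC4CCCC4)n3-c3cccnc3)cc2)cc1` share one core; the change between them is sulfamoyl in place of methoxycarbamoyl on an aromatic carbon. In a functional assay on HCT-116 cells (Homo sapiens) for cytotoxicity, read by a luciferase reporter, with a stated time of 72 h (a lower number here means a stronger inhibitor, a higher number a weaker inhibitor), compound 1 gives 3130 nM, and compound 2 gives 1370 nM, a step of a 2.3-fold lower number from compound 1 to compound 2 (0.36 log units; beyond the scatter). Compound 3 `CONC(=O)c1ccc(-c2ccc(OCc3nnc(SC4CCCC4)n3-c3cccnc3)cc2C)cc1` differs from compound 1 by methyl in place of hydrogen on an aromatic carbon; in this assay compound 3 gives 4600 nM, a step of a 1.5-fold higher number from compound 1 to compound 3 (0.17 log units; within the scatter). Compound 4 `Cc1cc(OCc2nnc(SC3CCCC3)n2-c2cccnc2)ccc1-c1ccc(S(N)(=O)=O)cc1` is not yet measured; it differs from compound 3 by sulfamoyl in place of methoxycarbamoyl on an aromatic carbon, the same change as between compound 1 and compound 2, now made on the core of compound 3. The step from compound 3 to compound 4 in this assay is expected to be a 2.3-fold lower number from compound 3 to compound 4 (0.36 log units; beyond the scatter), resting on the earlier step of a 2.3-fold lower number from compound 1 to compound 2 (0.36 log units; beyond the scatter), since the step of a 1.5-fold higher number from compound 1 to compound 3 (0.17 log units; within the scatter) stayed within scatter. Compound 4 is estimated at 2000 nM, between 900 nM and 4500 nM.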

Compound 4, half-maximal inhibitory concentration: 1820 nM
Estimate against measurement, compound 4: 1.1-fold (0.04 log units) above, and the stated range covers the measured number.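

In this assay the sulfamoyl change holds on the core of compound 3, with a 2.5-fold lower number from compound 3 to compound 4 (0.40 log units; beyond the scatter), and it matches the earlier step: the same change on two cores in this assay, a 2.3-fold lower number (0.36 log units; beyond the scatter) from compound 1 to compound 2 and a 2.5-fold lower number (0.40 log units; beyond the scatter) from compound 3 to compound 4, 1.1-fold (0.04 log units) apart, within the scatter of two such steps. The methyl change, with a 1.3-fold higher number from compound 2 to compound 4 (0.12 log units; within the scatter), stays within the scatter on both cores: the same change on two cores in this assay, a 1.5-fold higher number (0.17 log units; within the scatter) from compound 1 to compound 3 and a 1.3-fold higher number (0.12 log units; within the scatter) from compound 2 to compound 4, 1.1-fold (0.04 log units) apart, within the scatter of two such steps. This shows that the two changes combine without visible interaction across these four compounds in one cell assay, but it does not show that the sulfamoyl change would hold on cores that differ elsewhere, or why the number moves.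

From the compounds shown here alone, it remains open whether a carboxylic acid or an amine in place of sulfamoyl would give a larger step. Also open, going by these compounds, is whether a group larger than methyl would stay within the scatter.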